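The compounds below may be only part of what the source reports. "The series", "measured", "known", "first", "only" and "open" are said of these compounds alone.

Measured compounds:
Compound 1, `COc1ccccc1N1C(=O)CSC1C(=O)NCCCCc1ccccc1`: 60%
Compound 2, `COc1ccc(F)cc1N1C(=O)CSC1c1cccc(C(=O)NCCCCc2ccccc2)c1`: 86%

In a functional assay on MG-63 cells (Homo sapiens) for inhibition, read by CCK-8 assay, with a stated time of 72 h, tested at 1 uM (a higher number here means more inhibition at the concentration tested (going by the name of the read-out), a lower number less inhibition), compound 2 gives 86%, the higher of the two numbers. Compound 1 gives 60%, and the gap between the two compounds lies beyond the usual scatter of repeated measurements, so compound 2 stands clearly above compound 1 on the numbers at hand.

The next compound, compound 3, is `CCN1C(=O)CSC1c1cccc(C(=O)NCCCCc2ccccc2)c1`. It keeps the core of compound 2 and changes one place: ethyl in place of 5-fluoro-2-methoxyphenyl on an amide-type nitrogen in a ring. Among the compounds with values here, no measured pair shows this particular exchange, so the only guide is that the substituted phenyl on the ring nitrogen is part of the two compounds measured so far. Removing it in favour of a short chain is a sizeable change to the molecule. A step downward in this assay, beyond the scatter, is expected from compound 2 to compound 3, of the order of a number 28 percentage points lower from compound 2 to compound 3 (beyond the scatter). Compound 3 is therefore estimated to give 58% in this assay, within a range from 35% to 78%.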

Compound 3, a percentage reported as inhibition, at one concentration (the size of the read-out at that concentration, not a potency): 0%
Beside the measured number, compound 3's estimate is 58 percentage points above it, and the stated range ends above it.
By their numbers in this assay, from the lowest: compound 3; then compound 1; then compound 2.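

In this assay, putting ethyl in place of 5-fluoro-2-methoxyphenyl on the amide-type nitrogen in the ring gives a number 86 percentage points lower from compound 2 to compound 3 (beyond the scatter), with the rest of the molecule unchanged. Compound 1 and compound 2 both carry a substituted phenyl at this place, so they offered no view of what happens without one, whereas compound 3, at 0%, shows that this single exchange is enough to leave no inhibition at the concentration tested. This position therefore matters greatly in this series, although nothing at hand explains why the exchange has so large an effect.

The compounds shown leave open whether an aromatic ring is needed on this nitrogen or whether a larger group of another kind would serve, a question that an unsubstituted phenyl, a benzyl group and a longer chain such as hexyl could help to separate. They also leave open what the fluorine and the methoxy group each contribute, as the two leave together in this exchange.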